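Lengthening an Ester Chain: From Compound 1 to Compound 3

This account rests on a few compounds, and the source may have more. Where it says the series, first, only, none or still open, it means among the compounds named here.

Measured compounds:
Compound 1, `CCC(=O)Oc1ccc2oc(/C=C/[S+](C)[O-])cc(=O)c2c1`, gives 9000 nM.
Compound 2, `C[S+]([O-])/C=C/c1oc2ccccc2c(=O)c1Cc1ccccc1`, gives 5100 nM.

Both numbers come from a functional assay on DLD-1 cells (Homo sapiens) for cytotoxicity, with a stated time of 48 h; on this read-out higher numbers stand for weaker inhibition and lower numbers for stronger inhibition. Of the two values shown, compound 1 has the higher one, but compound 2 lies within the usual scatter of such measurements, so the two cannot be told apart on these numbers alone. Among the measured compounds shown here, nothing else separates them: the two structures differ in more than one place, so no single step between them can be described.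

The unmeasured compound 3, `CCCCC(=O)Oc1ccc2oc(/C=C/[S+](C)[O-])cc(=O)c2c1`, shares its core with compound 1 and differs from it only at the ester: ethyl in place of hydrogen on a saturated chain carbon, two bonds along the chain from a carbonyl carbon. For the measured compounds named here, no step of this kind between measured compounds is available, so the expectation rests only on the size of the change, which adds a short piece of chain and no new donor, acceptor or charge. The expected step of a 1.2-fold lower number from compound 1 to compound 3 (0.08 log units; within the scatter) is therefore one of no movement beyond the scatter, in either direction. Compound 3 is estimated at 7500 nM, with a range from 2500 nM to 25000 nM in this assay.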

Compound 3, half-maximal inhibitory concentration: 6700 nM
Beside the measured number, compound 3's estimate is 1.1-fold (0.05 log units) above it, and the stated range covers the measured number.
By their numbers in this assay, from the lowest: compounds 2, 3 and 1 (each within the scatter of the next).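

Among the compounds shown here, this is the first step that can be read at a single place: in this assay, ethyl in place of hydrogen on a saturated chain carbon, two bonds along the chain from a carbonyl carbon, gives a 1.3-fold lower number from compound 1 to compound 3 (0.13 log units; within the scatter). The same difference, cut one bond further out, reads propanoyl to butylcarbonyl, so this lengthening of the ester chain leaves the number within what repeated measurements would scatter over, something the earlier pair, differing in more than one place, could not show. Nothing measured on these compounds offers an explanation for this result.

The compounds shown leave open whether a longer chain at this position, such as hexanoyl, or a ring in its place, such as benzoyl, would also stay within the scatter, and a single step cannot establish a trend. They also leave open whether an amine or a carboxylic acid at the end of the chain would move the number beyond the scatter.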